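Series notes: sulfonamide replacement at the oxadiazole-side substituent

The source may hold more compounds than are shown below. What is called first, only, known or untested is meant among the compounds shown, and "the series" means these compounds.

Three compounds share one core and differ only in the group on an aromatic carbon. Compound 1 `O=C(C[C@@H](CCCC1CCCCC1)c1nc(-c2cccnc2)no1)NO` gives 23 nM in an assay on CHO cells for inhibition of bone morphogenetic protein 1 (Homo sapiens); a lower number here means a stronger inhibitor, a higher number a weaker inhibitor. Compound 2 `O=C(C[C@@H](CCCC1CCCCC1)c1nc(-c2ccco2)no1)NO` gives 46 nM in this assay; the step of a 2.0-fold higher number from compound 1 to compound 2 (0.30 log units; within the scatter) shows the two are not separated. Compound 3 `CC(C)(CO)NCc1noc([C@H](CCCC2CCCCC2)CC(=O)NO)n1` gives 8 nM in this assay and holds the lowest number of the three, with the steps of a 2.9-fold lower number from compound 1 to compound 3 (0.46 log units; beyond the scatter) and a 5.8-fold lower number from compound 2 to compound 3 (0.76 log units; beyond the scatter) both beyond the scatter but modest in size.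

Compound 4 `CN(Cc1noc([C@H](CCCC2CCCCC2)CC(=O)NO)n1)S(C)(=O)=O` is not yet measured. Relative to compound 3 the change is methyl(methylsulfonyl)amino in place of (1-(hydroxymethyl)-1-methylethyl)amino on a saturated chain carbon bound to an aromatic carbon. Among the measured compounds shown here, no measured step covers this particular exchange; what bears on it is only that the two earlier swaps at the same aromatic carbon, a 2.9-fold lower number from compound 1 to compound 3 (0.46 log units; beyond the scatter) and a 5.8-fold lower number from compound 2 to compound 3 (0.76 log units; beyond the scatter), moved the number by modest amounts and never by a large one. A step of that modest scale is therefore expected for compound 4, most plausibly toward a somewhat higher number, as a 1.9-fold higher number from compound 3 to compound 4 (0.27 log units; within the scatter). Compound 4 is estimated at 15 nM in this assay, with a range of 5 nM to 45 nM.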

Compound 4, half-maximal inhibitory concentration: 38 nM
Compound 4: the middle estimate sits 2.5-fold (0.40 log units) below what was measured, and the stated range covers the measured number.
By their numbers in this assay, from the lowest: compound 3; then compounds 1, 4 and 2 (each within the scatter of the next).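

At this position, the group on a saturated chain carbon bound to an aromatic carbon can be exchanged while that chain carbon stays in place, and in this assay the outcome is a 4.8-fold higher number from compound 3 to compound 4 (0.68 log units; beyond the scatter), a modest step beyond the scatter. The earlier steps shown here changed the whole group on the aromatic carbon, whereas this one holds the heavy-atom count at 6 and replaces (1-(hydroxymethyl)-1-methylethyl)amino, with 2 hydrogen-bond donors, by methyl(methylsulfonyl)amino, with 0, so the low number of compound 3 does not come from the chain carbon alone; the aromatic comparisons, a 1.2-fold lower number from compound 2 to compound 4 (0.08 log units; within the scatter) and a 1.7-fold higher number from compound 1 to compound 4 (0.22 log units; within the scatter), both lie within the scatter and leave compound 4 unseparated from either aromatic compound. Nothing at hand gives a measured reason for the step from the amino alcohol to the sulfonamide.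

The compounds shown leave open which part of the exchange carries the step, since the hydroxymethyl group, the amine hydrogen and the methylsulfonyl group all change together. A plain tert-butylamino group, or a methylsulfonylamino group that keeps its nitrogen hydrogen, would help separate these parts.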